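The compounds below may be only part of what the source reports. "The series", "measured", "known", "first", "only" and "open" are said of these compounds alone.

In a functional assay on MCF7 cells (Homo sapiens) for antiproliferative activity, read by MTT assay, with a stated time of 72 h (a higher number here means a weaker inhibitor, a lower number a stronger inhibitor), compound 1 `O=S(=O)(Oc1ccc(Br)cc1)C1CC2OC1C(c1ccc(/C=C/c3cc(O)cc(O)c3)cc1)=C2c1ccc(O)cc1` gives 16900 nM and compound 2 `O=S(=O)(Oc1ccccc1C(F)(F)F)C1CC2OC1C(c1ccc(/C=C/c3cc(O)cc(O)c3)cc1)=C2c1ccc(O)cc1` gives 18300 nM, two numbers within the scatter of each other. Compound 3 `O=S(=O)(Oc1ccc(O)cc1)C1CC2OC1C(c1ccc(/C=C/c3cc(O)cc(O)c3)cc1)=C2c1ccc(O)cc1` has 4-hydroxyphenyl in place of 2-(trifluoromethyl)phenyl on an oxygen. Among the measured compounds shown here, the one measured step bearing on this change, on the same oxygen, is a 1.1-fold higher number from compound 1 to compound 2 (0.03 log units; within the scatter). For the measured compounds named here, no measured compound carries 4-hydroxyphenyl there, so no step beyond the scatter is expected in this assay, and no direction is favoured. Compound 3 is estimated at 15000 nM, with an expected range of 6000 nM to 35000 nM. This estimate means an expected 1.2-fold lower number from compound 2 to compound 3 (0.09 log units; within the scatter).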

Compound 3, half-maximal inhibitory concentration: 14100 nM
The estimate for compound 3 lay 1.1-fold (0.03 log units) above the measured number, and the stated range covers the measured number.
By their numbers in this assay, from the lowest: compounds 3, 1 and 2 (each within the scatter of the next).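

In this assay, a hydroxy group on the aryl ring at this oxygen leaves the result within the scatter, with a 1.3-fold lower number from compound 2 to compound 3 (0.11 log units; within the scatter) and a 1.2-fold lower number from compound 1 to compound 3 (0.08 log units; within the scatter). Thus the entry of 4-hydroxyphenyl, which adds a hydrogen-bond donor and acceptor, separates compound 3 from neither compound 1 nor compound 2. No supporting data bear on this result.

Still open, on these data alone, is whether any group on this oxygen moves the number beyond the scatter. A phenyl ring carrying an amine or a carboxylic acid, or a longer alkyl chain in place of the aryl ring, could test this.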